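Compound 3: a new group on the ring nitrogen

The source may hold more compounds than are shown below. What is called first, only, known or untested is meant among the compounds shown, and "the series" means these compounds.

In a functional assay on PANC-1 cells (Homo sapiens) for inhibition, read by XTT assay, with a stated time of 72 h (a higher number here means a weaker inhibitor, a lower number a stronger inhibitor), compound 1 (`C=CCCCCCCCCCOC[C@@H]1CCCN1C(=O)OC(C)(C)C`) gives >= 100000 nM as a limit of the assay and not a number. For the measured compounds named here, compound 2 (`CCCCCCCC/C=C\CCCCCCCCOC[C@@H]1CCCN1C(=O)OC(C)(C)C`) gives 80000 nM and so holds the only true number so far. Going by the values given here, the one measured step (an at least 1.2-fold lower number from compound 1 to compound 2 (0.09 log units; that floor lies within the scatter)) has a floor within the scatter and alters the chain, so it sets no size for a change elsewhere. The other result is a limit (the limit of >= 100000 nM in this assay, at which 1 of the 2 values shown sits) and sets no size either.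

Compound 3 (`CCCCCCCC/C=C\CCCCCCCCOC[C@@H]1CCCN1[S+]([O-])c1ccc(C)cc1`) differs from compound 2 on an amine nitrogen in a ring (a group of 9 heavy atoms (7 carbon, 1 oxygen, 1 sulfur; one six-membered aromatic ring of carbon only) in place of a group of 7 heavy atoms (5 carbon, 2 oxygen; no ring), on an amine nitrogen in a ring) where tert-butoxycarbonyl leaves and a group with one six-membered aromatic ring of carbon only enters. Among the compounds with values here, no measured step touches that place, so the expected step (a 1.3-fold lower number from compound 2 to compound 3 (0.12 log units; within the scatter)) stays within the scatter in either direction. In this assay compound 3 is estimated at 60000 nM with an expected range from 20000 nM to 100000 nM for a repeated measurement.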

Compound 3, half-maximal inhibitory concentration: > 100000 nM
Compound 3 gave a limit, no number; the forecaster's own chance of this, stated with the estimate: 30%; middle value at least 1.6-fold (0.22 log units) away from the limit.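

In this assay compound 3 gives > 100000 nM as a limit of the assay and not a number. For the compounds shown here, the step of an at least 1.2-fold higher number from compound 2 to compound 3 (0.09 log units; that floor lies within the scatter) is the only reading so far at this place on the amine nitrogen in a ring, and it shows that the group with one six-membered aromatic ring of carbon only, in place of tert-butoxycarbonyl, does not bring a measurable value in this cell test. The real size of the step stays unknown because the reading of compound 3 stops at a limit: the limit of > 100000 nM in this assay, at which 1 of the 3 values shown sits.

The compounds shown leave open whether any group on this nitrogen can give a lower number than compound 2 does. A free ring amine or a small acetyl group at this place would help to settle that.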